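Topoisomerase series: phenyl in place of pyridin-3-yl

This account rests on a few compounds, and the source may have more. Where it says the series, first, only, none or still open, it means among the compounds named here.

Measured compounds:
compound 1 `Oc1ccc(-c2cc(-c3ccc(Cl)cc3)nc(-c3cccnc3)c2)cc1`: in an assay on isolated protein for inhibition of DNA topoisomerase 1 (Homo sapiens), with a stated time of 30 min, tested at 20 uM (a higher number here means a stronger effect of the compound at the concentration tested, a lower number a weaker effect), compound 1 gives "not determined" (no result reported)
compound 2 `Oc1ccc(-c2cc(-c3cccnc3)nc(-c3cccc(Cl)c3)c2)cc1`: in this assay compound 2 gives 0%

Compound 1 stands without a number in this assay; nothing was determined for it, so it gives no anchor. Going by the values given here, the only number is that of compound 2, which shows no inhibition at the tested concentration. Compound 3 `Oc1ccc(-c2cc(-c3ccccc3)nc(-c3ccc(Cl)cc3)c2)cc1` differs from compound 1 by phenyl in place of pyridin-3-yl on an aromatic carbon. Among the compounds with values here, no measured pair carries this change, so no step size is known; no shift beyond the scatter is expected in this assay. The expectation leans on compound 2 with 0%. Compound 3 is estimated at 5%, within 0% to 20%.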

Compound 3, a percentage reported as inhibition, at one concentration (the size of the read-out at that concentration, not a potency): 55.2%
Beside the measured number, compound 3's estimate is 50.2 percentage points below it, outside the stated range (above it).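

No step can be read between compound 1 and compound 3, as compound 1 gives "not determined" (no result reported). As far as these compounds go, the effect of phenyl in place of pyridin-3-yl on inhibition remains open. No available data bear on this result.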